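The source may hold more compounds than are shown below. What is called first, only, known or untested is meant among the compounds shown, and "the series" means these compounds.

Of the compounds shown here, three that share one core have been tested in an ADME assay on microsomes from liver (Homo sapiens) for metabolic stability, using NADPH, with a stated time of 60 min, in the presence of a further agent that is not named here; a higher number here means faster removal of the compound, a lower number slower removal. Compound 1 `O=C(O)COc1ccc([C@H]2CC[C@]3(CC2)OOC2(O3)C3CC4CC(C3)CC2C4)cc1Cl` gives < 7 mL.min-1.g-1, which is a limit of the assay and not a number. Compound 2 `O=C(O)c1cccc([C@H]2CC[C@]3(CC2)OOC2(O3)C3CC4CC(C3)CC2C4)c1` gives 12 mL.min-1.g-1. Compound 3 `O=C(O)c1cc([C@H]2CC[C@]3(CC2)OOC2(O3)C3CC4CC(C3)CC2C4)ccc1O` gives 108 mL.min-1.g-1, the higher of the two actual numbers, so it is removed fastest among the compounds with a number.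

Compound 4 `O=C(O)COc1ccc([C@H]2CC[C@]3(CC2)OOC2(O3)C3CC4CC(C3)CC2C4)cc1C(=O)O` differs from compound 3 in one place, with carboxymethyl in place of hydrogen on an oxygen on an aromatic ring. The free hydroxy thus becomes a carboxymethoxy group.

Within the data shown here, only one measured step bears directly on this change. Putting hydroxy in place of hydrogen on an aromatic carbon gave a 9.0-fold higher number from compound 2 to compound 3 (0.95 log units; beyond the scatter). Compound 4 no longer has that free hydroxy, so this rise may be largely lost. Compound 1 also carries a carboxymethoxy group, although it differs from compound 4 in another group as well.

The expected change is therefore a fall of similar size, an estimated 12-fold lower number from compound 3 to compound 4 (1.08 log units; beyond the scatter), which would lie beyond the scatter. The estimated value for compound 4 is 9 mL.min-1.g-1, with an expected range from 4 mL.min-1.g-1 to 30 mL.min-1.g-1.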

Compound 4, intrinsic clearance in microsomes in the Homo sapiens assay: < 7 mL.min-1.g-1
Compound 4 ended at the assay's limit; the forecaster's own chance of this, stated with the estimate: 45%; middle value at least 1.2-fold (0.10 log units) from the limit.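

In the Homo sapiens assay, the oxygen on an aromatic ring proves a sensitive place: carboxymethyl in place of its hydrogen gives an at least 15-fold lower number from compound 3 to compound 4 (1.18 log units; beyond the scatter), which shows that the fast removal of compound 3 does not survive this single change, while the comparison with the compound lacking the hydroxy altogether gives an at least 1.7-fold lower number from compound 2 to compound 4 (0.23 log units; that floor lies within the scatter), so compound 4 cannot be placed clearly below compound 2. Going by these compounds, the result for compound 4 is a limit of the assay and not a number, so the full size of its fall stays unknown: the limit of < 7 mL.min-1.g-1 in the Homo sapiens assay, at which 2 of the 4 values shown sit. In a physicochemical assay for lipophilicity, read by HPLC, at pH 7.4 (a higher number here means a more lipophilic compound, a lower number a more polar compound), compound 3 gives 3 and compound 4 gives 1.9. The same change also makes the compound more polar, and this may be part of why removal falls, though a single pair cannot separate the two effects: the measured distribution coefficient of compound 3, 3, and of compound 4, 1.9, a number 1.10 log units lower (beyond the scatter).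

The step between compound 1 and compound 4 joins two limits and cannot be read, so the compounds shown do not tell whether carboxy and chloro on that aromatic carbon differ at all. Also open, on these data alone, is whether the fall needs the carboxylic acid of the carboxymethyl group, or whether a methyl or a longer chain without that acid, on the same oxygen, would slow removal equally.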